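A few compounds are considered here, and "the series" means these few. Any claim that something is new, unique, unknown or untested is made for them only; others in the source may bear on it.

Measured in a functional assay on A549 cells (Homo sapiens) for inhibition, read by sulforhodamine B assay (on this read-out higher numbers stand for weaker inhibition of growth and lower numbers for stronger inhibition of growth), so far:
- compound 1 (`Clc1cccc(-c2ccc(-c3ccc(-c4nc5ccccc5[nH]4)cc3)cc2)c1`): 31100 nM
- compound 2 (`Oc1cccc2[nH]c(-c3ccc(-c4ccc(-c5ccccc5)cc4)cc3)nc12`): 8320 nM
- compound 3 (`CN(C)c1ccc(-c2ccc(-c3ccc(-c4nc5c(O)cccc5[nH]4)cc3)cc2)cc1`): 7100 nM

Compound 3 sits within the scatter of compound 2, while compound 1 has a clearly higher number. Compound 4 (`Oc1cccc2[nH]c(-c3ccc(-c4ccc(-c5cccc(Cl)c5)cc4)cc3)nc12`) carries 3-chlorophenyl in place of 4-(dimethylamino)phenyl on an aromatic carbon is the whole change. For the measured compounds named here, the one measured step bearing on it is a 1.2-fold lower number from compound 2 to compound 3 (0.07 log units; within the scatter) and it shows little effect. Compound 1 at 31100 nM also carries 3-chlorophenyl, on a differing core, which leaves room upward. A small rise in this assay is expected, within the scatter, with the estimated step being a 1.3-fold higher number from compound 3 to compound 4 (0.10 log units; within the scatter) overall. Compound 4 is estimated at 9000 nM (expected range 3500 nM to 25000 nM).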

Compound 4, concentration for 50% growth inhibition: 2400 nM
The estimate for compound 4 lay 3.8-fold (0.57 log units) above the measured number; measured number outside the range, below it.
By their numbers in this assay, from the lowest: compound 4; then compounds 3 and 2 (each within the scatter of the next); then compound 1.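

In this assay this place, on an aromatic carbon para to a large group, proves responsive: compound 3 stayed within the scatter of compound 2, yet the data show a 3.0-fold lower number from compound 3 to compound 4 (0.47 log units; beyond the scatter) for 3-chlorophenyl replacing 4-(dimethylamino)phenyl and a 3.5-fold lower number from compound 2 to compound 4 (0.54 log units; beyond the scatter) for chloro replacing hydrogen. Hydroxy in place of hydrogen on the core gives the largest step, a 13-fold lower number from compound 1 to compound 4 (1.11 log units; beyond the scatter), with 3-chlorophenyl kept. No evidence is available to explain these steps. On these data alone, whether a fluoro, a nitrile or a carboxylic acid in place of the chloro would give a similar step remains open.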